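The source may hold more compounds than are shown below. What is called first, only, known or untested is meant among the compounds shown, and "the series" means these compounds.

Compound 1, `Oc1ccc(-c2cc(-c3ccccc3O)cc(-c3cccc(O)c3)n2)cc1`: in a functional assay on HCT-15 cells (Homo sapiens) for cytotoxicity, read by CCK-8 assay, with a stated time of 4 days (on this read-out higher numbers stand for weaker inhibition and lower numbers for stronger inhibition), compound 1 gives 4850 nM.
Compound 2, `Oc1ccccc1-c1cc(-c2ccccc2O)nc(-c2ccccc2O)c1`: in this assay compound 2 gives 2180 nM.
Compound 3, `Oc1cccc(-c2cc(-c3ccccc3O)cc(-c3ccccc3O)n2)c1`: in this assay compound 3 gives 3390 nM.

Compound 3 stands second highest of the three numbers in this assay. Its nearest neighbour is compound 1, with a 1.4-fold lower number from compound 1 to compound 3 (0.16 log units; within the scatter), and its furthest is compound 2, with a 1.6-fold higher number from compound 2 to compound 3 (0.19 log units; within the scatter); neither gap is beyond the scatter, so the three compounds cannot be ordered on these numbers.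

Compound 4, `Oc1ccc(-c2cc(-c3cccc(O)c3)nc(-c3ccccc3O)c2)cc1`, has the same atoms as compound 3 joined differently: 4-hydroxyphenyl in place of 2-hydroxyphenyl on an aromatic carbon. For the measured compounds named here, the closest measured step is the one from compound 1 to compound 3, which exchanges the same two groups in the opposite direction and stays within the scatter. The step from compound 2 to compound 3 also concerns a change of one hydroxyphenyl for another and likewise stays within the scatter. From this, no step beyond the scatter is expected in this assay, in either direction. The estimate for compound 4 in this assay is therefore 4000 nM, with a range from 2000 nM to 8000 nM. This estimate corresponds to an expected step of a 1.2-fold higher number from compound 3 to compound 4 (0.07 log units; within the scatter).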

Compound 4, half-maximal inhibitory concentration: 5830 nM
Estimate against measurement, compound 4: 1.5-fold (0.16 log units) below, and the stated range covers the measured number.
By their numbers in this assay, from the lowest: compounds 2, 3, 1 and 4 (each within the scatter of the next, the first and the last beyond it).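

In this assay, the exchange of 2-hydroxyphenyl for 4-hydroxyphenyl on the carbon opposite the ring nitrogen gives a 1.7-fold higher number from compound 3 to compound 4 (0.24 log units; within the scatter) and so stays inside the usual variation between repeats. For the compounds shown here, compounds 1, 2 and 3 all carry 2-hydroxyphenyl at this place, so this step is the first reading of a change there, and it shows that moving the hydroxyl around this ring from one printed position to the other produces no resolvable difference on this read-out. Nothing available explains the size of this step or says what the hydroxyl contributes at this place.

Still open, on these data alone, is how 3-hydroxyphenyl would read opposite the ring nitrogen, which would complete the set of three hydroxyphenyl groups at this place. As far as these compounds go, it is equally open whether a group of a different kind there, such as a phenyl ring carrying an amine or a carboxylic acid in place of the hydroxyl, or an unsubstituted phenyl ring, would give a step beyond the scatter in this assay.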